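A few compounds are considered here, and "the series" means these few. Any claim that something is new, unique, unknown or untested is made for them only; others in the source may bear on it.

Values in a functional assay on the whole organism (strain Hartley) for inhibition, with Cavia porcellus as the target, with stated times of 15 min and 2 min (a higher number here means that more compound is needed for the effect, a lower number that less compound is needed), stand as follows
compound 1 (`CCCCC1([C@@H](O)/C=C/C2[C@H](O)CC(=O)[C@@H]2CCCCCCC(=O)O)CCC1`): 0.03 mg/kg
compound 2 (`CCCCC1([C@H](O)/C=C/C2CCC(=O)[C@@H]2CCCCSCC(=O)OCC)CCC1`): 0.909 mg/kg
compound 3 (`CCCC1([C@H](O)/C=C/C2[C@H](O)CC(=O)[C@@H]2C/C=C\CCCC(=O)O)CCC1`): 0.003 mg/kg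

Compound 2 (0.909 mg/kg) holds the highest of the three numbers, beyond the scatter from both others, with compound 1 nearest and compound 3 furthest. Compound 4 (`CCCCC1([C@H](O)/C=C/C2CCC(=O)[C@@H]2CCCCCCC(=O)O)CCC1`) differs from compound 2 by one change: 2-carboxyethyl in place of ((ethoxycarbonyl)methyl)sulfanyl on a saturated chain carbon, four bonds along the chain from a saturated ring carbon. Within the data shown here, no measured pair isolates this change. Compound 1 (0.03 mg/kg) and compound 3 (0.003 mg/kg) both end their chains in a carboxylic acid and stand lower, though both also differ from compound 2 elsewhere. A lower number beyond the scatter is therefore expected in this assay: a 4.5-fold lower number from compound 2 to compound 4 (0.66 log units; beyond the scatter) as estimated here. Compound 4 is estimated at 0.2 mg/kg within an expected range from 0.04 mg/kg to 1 mg/kg for this measurement.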

Compound 4, dose for half-maximal effect: 47.8 mg/kg
Estimate against measurement, compound 4: 240-fold (2.38 log units) below; the whole stated range lies below it.
By their numbers in this assay, from the lowest: compound 3; then compound 1; then compound 2; then compound 4.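

In this assay, the exchange of ((ethoxycarbonyl)methyl)sulfanyl for 2-carboxyethyl on a saturated chain carbon, four bonds along the chain from a saturated ring carbon, gives a 53-fold higher number from compound 2 to compound 4 (1.72 log units; beyond the scatter). This position is therefore highly sensitive to the exchange, and a chain ending in a carboxylic acid does not by itself bring a lower number here. Nothing available accounts for the direction or size of this step. As far as these compounds go, the step changes the sulfur and the chain end together, so their separate contributions remain open. An ethyl ester on the all-carbon chain, or a carboxylic acid on the sulfanyl chain, would separate them.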